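The source may hold more compounds than are shown below. What is called first, only, known or untested is meant among the compounds shown, and "the series" means these compounds.

Measured in a functional assay on DLD-1 cells (Homo sapiens) for antiproliferative activity, read by CellTiter-Glo, with a stated time of 72 h; a lower number here means a stronger inhibitor, a higher number a weaker inhibitor:

Compound 1 `Cc1cc(C)c(S(=O)(=O)N2CCC(N3CCC(c4ccccc4)CC3)CC2)c(C)c1` gives 865 nM.
Compound 2 `CC1CCN(C2CCN(S(=O)(=O)c3ccccc3-c3ccc(C(F)(F)F)cc3)CC2)CC1` gives 122 nM.
Compound 3 `CC1CCN(C2CCN(S(=O)(=O)c3nccn3C)CC2)CC1` reaches only a limit of the assay, > 5000 nM.

Of the two numbers shown, compound 1 has the higher one; compound 2 lies lower, and that gap is beyond the usual scatter. Compound 3 sits at the limit of > 5000 nM in this assay, at which 1 of the 3 values shown sits.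

Compound 4 `Cc1cc(C)c(S(=O)(=O)N2CCC(N3CCC(C(C)C)CC3)CC2)c(C)c1` differs from compound 1 in one place: isopropyl in place of phenyl on a saturated ring carbon. Among the measured compounds shown here, no measured pair tells what this change does. The step is estimated as a 1.7-fold higher number from compound 1 to compound 4 (0.24 log units; within the scatter), a modest move toward a weaker inhibitor, with the chance that it goes either way. Compound 4 is therefore expected to give 1500 nM, within 400 nM to 6000 nM.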

Compound 4, half-maximal inhibitory concentration: 0.3 nM
For compound 4 the middle estimate is 5000-fold (3.70 log units) above the measured one, and the stated range ends above it.
By their numbers in this assay, from the lowest: compound 4; then compound 2; then compound 1. At a limit, above all of these: compound 3.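

Isopropyl in place of phenyl on a saturated ring carbon gives a 2900-fold lower number from compound 1 to compound 4 (3.46 log units; beyond the scatter) in this assay. Among the compounds shown here, this shows that the group at this position, three ring bonds from the ring nitrogen, can by itself govern the result, which no earlier pair of compounds could show. Nothing measured here gives a cause for the step.

From the compounds shown here alone, what remains open is whether the gain needs isopropyl itself or simply the loss of the phenyl ring. Cyclohexyl, tert-butyl or an amine at this position would begin to separate those readings.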